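This account rests on a few compounds, and the source may have more. Where it says the series, first, only, none or still open, it means among the compounds named here.

Notes on the series. Compound 3 `O=C(S[C@]12CCC[C@H]1C(=O)NC2=O)c1ccccc1Cl` and compound 2 `O=C(S[C@]12CCC[C@H]1C(=O)NC2=O)c1ccc(F)cc1` share a core; how the two cores differ beyond the aryl substitution is not broken down here. In a functional assay on RAW264.7 cells (Mus musculus) for inhibition, read by Griess assay, with a stated time of 24 h (a lower number here means a stronger inhibitor, a higher number a weaker inhibitor), compound 3 gives 59800 nM, and compound 2 gives 390000 nM, the highest number among the three measured compounds. Compound 1 `O=C(S[C@]12CC[C@H](O)[C@H]1C(=O)NC2=O)c1ccccc1Cl` carries a hydroxy on the core of compound 3, the difference being (hydroxy in place of hydrogen on a saturated ring carbon). In this assay compound 1 gives 178000 nM; the step is a 3.0-fold higher number from compound 3 to compound 1 (0.47 log units; beyond the scatter).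

Compound 4 `O=C(S[C@]12CC[C@H](O)[C@H]1C(=O)NC2=O)c1ccc(F)cc1` is compound 2 with the same change, (hydroxy in place of hydrogen on a saturated ring carbon); the place lines of the two changes read the same word for word, so this is taken as the same change on a different core, seen twice in all among these compounds. Among the measured compounds shown here, no measured step exists between compound 2 and compound 3; their values alone show compound 2 the weaker. For the measured compounds named here, from compound 2 to compound 4 a step of about a 2.6-fold higher number from compound 2 to compound 4 (0.41 log units; beyond the scatter) is expected, resting on the single earlier step of a 3.0-fold higher number from compound 3 to compound 1 (0.47 log units; beyond the scatter) in this assay. For compound 4 in this assay the estimate is 1000000 nM, expected to lie between 400000 nM and 2500000 nM.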

Compound 4, half-maximal inhibitory concentration: 318000 nM
Compound 4: the middle estimate sits 3.1-fold (0.50 log units) above what was measured, outside the stated range (below it).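

The hydroxy in place of hydrogen on a saturated ring carbon does not carry over as one fixed step in this assay; on the 4-fluorophenyl side the new step is a 1.2-fold lower number from compound 2 to compound 4 (0.09 log units; within the scatter), and set beside the 2-chlorophenyl pair it reads: the same change on two cores in this assay, a 3.0-fold higher number (0.47 log units; beyond the scatter) from compound 3 to compound 1 and a 1.2-fold lower number (0.09 log units; within the scatter) from compound 2 to compound 4, 3.7-fold (0.56 log units) apart, beyond the scatter of two such steps

With the hydroxy present, the exchange of the aryl group gives a 1.8-fold higher number from compound 1 to compound 4 (0.25 log units; within the scatter), so these two aryl groups are not told apart on the hydroxy-bearing core. Among the compounds shown here, this shows that, for these four compounds, the size of the hydroxy step depends on which aryl group sits on the carbonyl carbon, but with only two pairs it gives no reason for that and no rule for any other aryl group.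

As far as these compounds go, it remains open whether a third aryl group, such as unsubstituted phenyl or 4-chlorophenyl, would follow the pair of compound 3 and compound 1 or the pair of compound 2 and compound 4. Also open, from the compounds shown here alone, is how an amine or a methoxy group on the same saturated ring carbon would compare with the hydroxy.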